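A few compounds are considered here, and "the series" means these few. Any claim that something is new, unique, unknown or untested is made for them only; others in the source may bear on it.

Compound 2 `COc1ccc(OCC(=O)N2CCN(c3ccc(C(F)(F)F)cc3[C@@H](N)CC(C)C)CC2)cc1` is a piperazine amide that carries a 4-methoxyphenyl group on an oxygen on a saturated carbon. In an assay on HEK293 cells for displacement of a labelled ligand from Melanocortin receptor 4 (Homo sapiens) (on this read-out higher numbers stand for weaker inhibition and lower numbers for stronger inhibition), compound 2 gives 3800 nM. Among the three numbers recorded, compound 2 stands second highest. Its nearest neighbour is compound 3 `Cc1ccc(OCC(=O)N2CCN(c3ccc(C(F)(F)F)cc3[C@@H](N)CC(C)C)CC2)cc1`, which gives 4400 nM; the step of a 1.2-fold higher number from compound 2 to compound 3 (0.06 log units; within the scatter) is a single exchange of one small aromatic substituent for another and does not leave the scatter. Among the measured compounds shown here, the furthest is compound 1 `CC(C)C[C@H](N)c1ccccc1N1CCN(C(=O)[C@H](C)Cc2ccc(Cl)cc2F)CC1`, built on a different amide portion, which gives 67 nM; no single-point step connects it to compound 2.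

Compound 4 `CC(C)C[C@H](N)c1cc(C(F)(F)F)ccc1N1CCN(C(=O)COc2cccc3ccccc23)CC1` differs from compound 2 by naphthalen-1-yl in place of 4-methoxyphenyl on an oxygen on a saturated carbon. For the measured compounds named here, the only measured step that touches the same region of the molecule is a 1.2-fold higher number from compound 2 to compound 3 (0.06 log units; within the scatter), and that one, within the scatter, alters only the substituent on the aromatic ring rather than the ring itself. Going by the values given here, no recorded pair replaces the entire ring with a second fused aromatic ring, so the data give no direct precedent for the size of this move. On that basis the step from compound 2 to compound 4 is expected to stay within the scatter, amounting to a 1.3-fold lower number from compound 2 to compound 4 (0.10 log units; within the scatter). Compound 4 is therefore estimated at 3000 nM, with a likely range from 1000 nM to 9000 nM.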

Compound 4, inhibition constant: 2600 nM
Compound 4: middle estimate off by 1.2-fold (0.06 log units), on the high side, within the range that was stated.
By their numbers in this assay, from the lowest: compound 1; then compounds 4, 2 and 3 (each within the scatter of the next).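

Compound 3 and compound 2 differ only in a small substituent on one aromatic ring, whereas compound 4 replaces that whole aryl group on the oxygen on a saturated carbon with naphthalen-1-yl. This larger change adds a second six-membered aromatic ring and leaves out the methoxy oxygen, yet in this assay neither comparison leaves the scatter: a 1.5-fold lower number from compound 2 to compound 4 (0.16 log units; within the scatter) and a 1.7-fold lower number from compound 3 to compound 4 (0.23 log units; within the scatter). Among these three compounds, which share everything except this group, the exchange of a single ring for a fused pair therefore has no readable effect on the number, and nothing at hand accounts for that outcome.

The compounds shown leave open whether a group of another kind at this place, such as a carboxylic acid, an amine or a pyridine ring, would move the number beyond the scatter, and whether naphthalen-2-yl would behave as naphthalen-1-yl does. Among the compounds shown here, they also leave open which of its several differences from the other compounds goes with the value of compound 1, 67 nM, since no single step connects it to them.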